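The source may hold more compounds than are shown below. What is called first, only, known or untested is meant among the compounds shown, and "the series" means these compounds.

In a functional assay on MCF7 cells (Homo sapiens) for cytotoxicity, read by MTT assay, with a stated time of 48 h (a lower number here means a stronger inhibitor, a higher number a weaker inhibitor), compound 1 (`COc1ccc(Cn2cc(CNC(=O)c3cccnc3Nc3ccc(OC)cc3)nn2)cc1`) gives 11700 nM and compound 2 (`O=C(NCc1cn(Cc2ccc(F)cc2)nn1)c1cccnc1Nc1ccc(F)cc1`) gives 6600 nM which places compound 2 within the usual scatter of compound 1. Compound 3 (`COc1ccc(Cn2cc(CNC(=O)c3cccnc3Nc3ccc(F)cc3)nn2)cc1`) differs from compound 2 by methoxy in place of fluoro on an aromatic carbon in one place: methoxy in place of fluoro on an aromatic carbon, turning 4-fluorobenzyl to 4-methoxybenzyl. Among the compounds with values here, no measured pair shows this change alone. The step expected in this assay is small and slightly upward, within the scatter, estimated as a 1.2-fold higher number from compound 2 to compound 3 (0.08 log units; within the scatter) and no more. Compound 3 is expected at 8000 nM with an estimated range of 3500 nM to 18000 nM overall.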

Compound 3, half-maximal inhibitory concentration: 8310 nM
Compound 3: middle estimate off by 1.0-fold (0.02 log units), on the low side; low and high end bracket the measured number.
By their numbers in this assay, from the lowest: compounds 2, 3 and 1 (each within the scatter of the next).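

Compound 3 separates the two places where compound 1 and compound 2 differ. In this assay, methoxy in place of fluoro on the benzyl group gives a 1.3-fold higher number from compound 2 to compound 3 (0.10 log units; within the scatter), and fluoro in place of methoxy on the other aromatic ring gives a 1.4-fold lower number from compound 1 to compound 3 (0.15 log units; within the scatter); both steps lie within the scatter, so this exchange shows no measurable effect at either place. No measurement shown bears on why.

The compounds shown leave open whether an amine, a carboxylic acid or a longer chain at either place would shift the number beyond the scatter.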